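Bromo to ethynyl on the phenyl amide series

A few compounds are considered here, and "the series" means these few. Any claim that something is new, unique, unknown or untested is made for them only; others in the source may bear on it.

Measured in a functional assay on HCT-116 cells (Homo sapiens) for antiproliferative activity, read by MTT assay, with a stated time of 72 h; on this read-out lower numbers stand for stronger inhibition and higher numbers for weaker inhibition:
Compound 1 `O=C(CCc1cccc2c1B(O)OC2)Nc1nccs1`: > 100000 nM, a limit
Compound 2 `O=C(CCc1cccc2c1B(O)OC2)Nc1ccc(Cl)cc1`: 12000 nM
Compound 3 `O=C(CCc1cccc2c1B(O)OC2)Nc1ccc(Br)cc1`: 46000 nM

Among the two values that are true numbers, compound 3 stands higher, at 46000 nM. The gap to its nearest neighbour is a 3.8-fold higher number from compound 2 to compound 3 (0.58 log units; beyond the scatter).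

Compound 4 `C#Cc1ccc(NC(=O)CCc2cccc3c2B(O)OC3)cc1` has ethynyl in place of bromo on an aromatic carbon, para to a large group: ethynyl in place of bromo on an aromatic carbon. Going by the values given here, the closest precedent is the swap at that same place, a 3.8-fold higher number from compound 2 to compound 3 (0.58 log units; beyond the scatter), which is modest but beyond the scatter. The steps of an at least 8.3-fold lower number from compound 1 to compound 2 (0.92 log units; beyond the scatter) and an at least 2.1-fold lower number from compound 1 to compound 3 (0.33 log units; beyond the scatter) replace the whole group on the amide-type nitrogen, so they bear on the change less directly. Among the compounds with values here, no measured compound carries ethynyl, so the direction is uncertain. A modest step in this assay is expected, leaning toward a lower number, since compound 2 reaches 12000 nM with a different group at this place. The expected change is a 1.8-fold lower number from compound 3 to compound 4 (0.26 log units; within the scatter). Compound 4 is estimated at 25000 nM, with an expected range of 7000 nM to 90000 nM.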

Compound 4, half-maximal inhibitory concentration: 45000 nM
Estimate against measurement, compound 4: 1.8-fold (0.26 log units) below; measured number inside the range.
By their numbers in this assay, from the lowest: compound 2; then compounds 4 and 3 (each within the scatter of the next). At a limit, above all of these: compound 1.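

In this assay, the step of a 1.0-fold lower number from compound 3 to compound 4 (0.01 log units; within the scatter) shows that, on this aromatic carbon para to a large group, ethynyl can stand in place of bromo with a difference that stays within the scatter. The step of a 3.8-fold higher number from compound 2 to compound 4 (0.57 log units; beyond the scatter) lies beyond the scatter and is a modest one, so the chloro group of compound 2 remains apart from ethynyl as it did from bromo, and the gap does not depend on bromo alone. Nothing given here accounts for these differences.

The compounds shown leave open whether fluoro, methoxy or an amine at this place would give numbers nearer to that of compound 2 or to those of compound 3 and compound 4. They also leave open whether a longer chain between the core and the amide would alter the numbers of this phenyl amide series.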